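The source may hold more compounds than are shown below. What is called first, only, known or untested is meant among the compounds shown, and "the series" means these compounds.

Working notes on the series. All three measured compounds share one core and differ only in the amine substituent on it. Compound 1 `Cc1nc(-c2cnc(N(C)C)[nH]c2=O)ccc1Oc1ccnc(-c2cnn(C)c2)c1` gives 716 nM in a functional assay on NFS-60 cells (Mus musculus) for antiproliferative activity, read by resazurin assay, with a stated time of 72 h; a lower number here means a stronger inhibitor, a higher number a weaker inhibitor. Compound 2 `Cc1nc(-c2cnc(N3CCCC3)[nH]c2=O)ccc1Oc1ccnc(-c2cnn(C)c2)c1` gives 56 nM in this assay, and compound 3 `CNc1ncc(-c2ccc(Oc3ccnc(-c4cnn(C)c4)c3)c(C)n2)c(=O)[nH]1` gives 1300 nM in this assay. Compound 3 thus carries the highest of the three numbers; its gap to compound 1 stays within the scatter, whereas the step of a 23-fold higher number from compound 2 to compound 3 (1.37 log units; beyond the scatter) is large. The other large step, a 13-fold lower number from compound 1 to compound 2 (1.11 log units; beyond the scatter), runs the same way, with the ring-bearing amine at the low end. The step of a 1.8-fold higher number from compound 1 to compound 3 (0.26 log units; within the scatter) is small.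

Compound 4 `Cc1nc(-c2cnc(NC3CCOCC3)[nH]c2=O)ccc1Oc1ccnc(-c2cnn(C)c2)c1` differs from compound 3 by oxan-4-yl in place of methyl on a nitrogen on an aromatic ring. Both large steps bear on this change, as each swapped the amine substituent and the ring-bearing group gave the lower number in this assay. A lowering beyond the scatter is therefore expected in this assay, estimated as a 5.2-fold lower number from compound 3 to compound 4 (0.72 log units; beyond the scatter), though with uncertainty since no ring on the amine nitrogen through a single carbon has been measured. Compound 4 is expected to give 250 nM in this assay, within 70 nM to 900 nM.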

Compound 4, half-maximal inhibitory concentration: 413 nM
For compound 4 the middle estimate is 1.7-fold (0.22 log units) below the measured one; the measured number falls inside the stated range.
By their numbers in this assay, from the lowest: compound 2; then compounds 4, 1 and 3 (each within the scatter of the next, the first and the last beyond it).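

In this assay, the first ring held on the amine nitrogen through a single carbon gives a 3.1-fold lower number from compound 3 to compound 4 (0.50 log units; beyond the scatter) and thus only part of what the ring of compound 2 gives, as a 7.4-fold higher number from compound 2 to compound 4 (0.87 log units; beyond the scatter) shows. Set against dimethylamino, the same group gives a 1.7-fold lower number from compound 1 to compound 4 (0.24 log units; within the scatter) and stays within the scatter, so the presence of a ring on the amine does not by itself bring the number down to that of compound 2. No measurement on hand accounts for these differences.

Still open, going by these compounds, is whether the low number of compound 2 goes with any ring closed through the amine nitrogen or with pyrrolidin-1-yl alone, which piperidin-1-yl and morpholin-4-yl would test. Cyclohexylamino would show what the ring oxygen of oxan-4-yl contributes.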